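The compounds below may be only part of what the source reports. "The series", "measured", "known", "first", "only" and "open" are said of these compounds alone.

Measured compounds, all in an assay on RPMI-8866 cells for inhibition of integrin alpha-4/beta-1 (Homo sapiens); a lower number here means a stronger inhibitor, a higher number a weaker inhibitor:
- Compound 1 `CC(C)[C@@H](CC(=O)O)NC(=O)[C@@H]1CCCN1S(=O)(=O)c1cc(Cl)cc(Cl)c1` gives 8.9 nM
- Compound 2 `C/C=C/[C@@H](CC(=O)O)NC(=O)[C@@H]1CCCN1S(=O)(=O)c1cc(Cl)cc(Cl)c1` gives 13 nM
- Compound 3 `O=C(O)C[C@@H](NC(=O)[C@@H]1CCN1S(=O)(=O)c1cc(Cl)cc(Cl)c1)c1ccc(F)cc1` gives 3.2 nM

Among these three numbers compound 1 holds the second highest. Its nearest neighbour is compound 2, and the step of a 1.5-fold higher number from compound 1 to compound 2 (0.16 log units; within the scatter) stays within the scatter of the method. Compound 3 sits furthest away, with a lower number that lies beyond the scatter. Within the data shown here, compound 3 differs from compound 1 in two places at once, so no single step between them can be read off.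

Compound 4 `O=C(O)C[C@@H](NC(=O)[C@@H]1CCCN1S(=O)(=O)c1cc(Cl)cc(Cl)c1)c1ccc(O)cc1` has not been measured in this assay. It differs from compound 1 in one place: 4-hydroxyphenyl in place of isopropyl on a saturated chain carbon bound to an amide-type nitrogen and a saturated chain carbon. Among the measured compounds shown here, only one measured step touches this position, a 1.5-fold higher number from compound 1 to compound 2 (0.16 log units; within the scatter), and it is too small to count. That compound 3, which also carries an aromatic ring at this position, reaches 3.2 nM hints that a ring is at least tolerated there, though its other difference clouds the comparison. The expected outcome is therefore a step of a 1.5-fold lower number from compound 1 to compound 4 (0.17 log units; within the scatter), modest and uncertain in direction. The estimate for compound 4 in this assay is 6 nM, in a range from 2 nM to 18 nM.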

Compound 4, half-maximal inhibitory concentration: 0.74 nM
Compound 4: middle estimate off by 8.1-fold (0.91 log units), on the high side; the whole stated range lies above it.
By their numbers in this assay, from the lowest: compound 4; then compound 3; then compounds 1 and 2 (each within the scatter of the next).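

In this assay the position on a saturated chain carbon bound to an amide-type nitrogen and a saturated chain carbon proves highly sensitive to the group placed there: 4-hydroxyphenyl in place of isopropyl gives a 12-fold lower number from compound 1 to compound 4 (1.08 log units; beyond the scatter) and in place of prop-1-en-1-yl gives an 18-fold lower number from compound 2 to compound 4 (1.24 log units; beyond the scatter) with the rest of the molecule unchanged. Among these compounds, the only earlier step here, a 1.5-fold higher number from compound 1 to compound 2 (0.16 log units; within the scatter) on exchanging one open chain for another, gave no sign that this position could separate compounds by so wide a margin. Nothing available explains why this change has so large an effect.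

From the compounds shown here alone, it remains open whether the aromatic ring alone or the hydroxyl on it accounts for the step, and how plain phenyl or 4-methoxyphenyl would compare on the core of compound 1. Compound 3 differs from compound 4 in two places, so it cannot settle this question.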